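The source may hold more compounds than are shown below. What is called first, only, known or untested is meant among the compounds shown, and "the series" means these compounds.

In a functional assay on A549 cells (Homo sapiens) for antiproliferative activity, read by MTT assay (a higher number here means a weaker inhibitor, a lower number a stronger inhibitor), compound 3 `CC1(C)CCc2c(ccc(C(=O)/C=C/c3ccc(OCc4cn(-c5ccc(Cl)cc5)nn4)cc3)c2O)O1` is recorded as "not active" (no number reported), so it offers no number to start from. Two relatives with a different core do have numbers: compound 1 `CC1(C)CCc2cc(C(=O)/C=C/c3ccc(OCc4cn(-c5ccc(Cl)cc5)nn4)cc3)c(O)cc2O1` gives 75500 nM and compound 2 `CC(=O)c1ccc(-n2cc(COc3ccc(/C=C/C(=O)c4cc5c(cc4O)OC(C)(C)CC5)cc3)nn2)cc1` gives 66300 nM. Compound 4 `CC(=O)c1ccc(-n2cc(COc3ccc(/C=C/C(=O)c4ccc5c(c4O)CCC(C)(C)O5)cc3)nn2)cc1` differs from compound 3 in one place, with 4-chlorophenyl becoming 4-acetylphenyl: acetyl in place of chloro on an aromatic carbon. For the measured compounds named here, only one measured step bears on this swap. On the other core it gave a 1.1-fold lower number from compound 1 to compound 2 (0.06 log units; within the scatter), so no step beyond the scatter is expected in this assay here. Compound 4 may therefore also be reported without a number. If a number is obtained, the estimate for compound 4 is 90000 nM, within an expected range of 50000 nM to 200000 nM.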

Compound 4, half-maximal inhibitory concentration: 149000 nM
The estimate for compound 4 lay 1.7-fold (0.22 log units) below the measured number, and the stated range covers the measured number.
By their numbers in this assay, from the lowest: compounds 2, 1 and 4 (each within the scatter of the next, the first and the last beyond it).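

No new step can be read: in this assay compound 3 has no number to set against compound 4. How far 4-acetylphenyl in place of 4-chlorophenyl shifts activity on the core of compound 3 stays open, and no measurement shown explains these values.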